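This account rests on a few compounds, and the source may have more. Where it says the series, first, only, none or still open, it means among the compounds named here.

Measured compounds:

Compound 1 `CN1CCc2cc(Cl)c(NS(=O)(=O)c3ccc(-c4ccc(Cl)cc4)cc3)cc2CC1`: 50.1 nM
Compound 2 `CCCCc1ccc(S(=O)(=O)Nc2ccc3c(c2)CCN(C)CC3)cc1`: 1.26 nM
Compound 3 `CCCCc1ccc(S(=O)(=O)Nc2ccc3c(c2)CNC3)cc1`: 50.1 nM

All three were tested in an assay on isolated protein for displacement of a labelled ligand from 5-hydroxytryptamine receptor 6 (Homo sapiens), read by radioligand binding; on this read-out higher numbers stand for weaker inhibition and lower numbers for stronger inhibition. Compound 1 gives 50.1 nM, the same number as compound 3, and together these two stand highest among the three. Among the measured compounds shown here, compound 2 gives 1.26 nM, a far lower number than compound 1 at 50.1 nM, a gap that lies well beyond the usual scatter of such measurements; no single-point step between these two is given, so only the two numbers themselves can be compared.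

The new compound 4 `CN1CCc2cc(Br)c(NS(=O)(=O)c3ccc(-c4ccc(Cl)cc4)cc3)cc2CC1` differs from compound 1 in one place: bromo in place of chloro on an aromatic carbon. For the measured compounds named here, no measured pair in this set shows what such an exchange does in this assay. Swapping one halogen for the other at the same position is a small change, and the step expected, a 1.3-fold lower number from compound 1 to compound 4 (0.10 log units; within the scatter), is one of no clear direction and not beyond the scatter. Compound 4 is therefore estimated at 40 nM, with a likely range from 15 nM to 120 nM.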

Compound 4, inhibition constant: 50.1 nM
Compound 4: middle estimate off by 1.3-fold (0.10 log units), on the low side, within the range that was stated.
By their numbers in this assay, from the lowest: compound 2; then compounds 1, 3 and 4 (each within the scatter of the next).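

Measured by this assay the exchange of chloro for bromo on this aromatic carbon, ortho to a large group, brings no change at the digits printed from compound 1 to compound 4 (within the scatter). Among the compounds shown here, this is the first pair in the set that differs in one place, so it is the first direct reading of this position: here the two halogens cannot be told apart, and the larger bromine atom leaves the number where it was. Nothing measured here explains why the two halogens read alike.

The compounds shown leave open what a plain hydrogen, a methyl group, a methoxy group or an amine would do on this same carbon, since only chloro and bromo appear there. They also leave open whether bromo could replace the second chloro, which compound 1 and compound 4 share, with as little change.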